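The compounds below may be only part of what the source reports. "The series", "measured", "known", "first", "only" and "open" are said of these compounds alone.

Compound 1, `C=CCOc1c(Cl)cccc1C(=O)c1cccnc1`: > 100000 nM
Compound 2, `C=CCOc1ccc(Cl)cc1C(=O)c1cccnc1`: 54000 nM

Of the compounds shown here, two have been measured in a functional assay on MCF7 cells (Homo sapiens) for cytotoxicity, read by sulforhodamine B assay, with a stated time of 48 h; a lower number here means a stronger inhibitor, a higher number a weaker inhibitor. Compound 1 gives only a limit there, > 100000 nM, so the assay reports no number for it; it sits at the limit of > 100000 nM in this assay, at which 1 of the 2 values shown sits. Going by the values given here, compound 2 is the one compound with a number, 54000 nM, and so it is the single point from which to start; it is a weak inhibitor in this assay. Compound 3, `C=CCOc1ccccc1C(=O)c1cccnc1`, has not yet been measured in this assay. It differs from compound 2 in one place: hydrogen in place of chloro on an aromatic carbon. Among the compounds with values here, no measured pair in this set shows what such a change does, so no size of effect can be read from the data. The expected step is a 1.4-fold higher number from compound 2 to compound 3 (0.14 log units; within the scatter), small and possibly toward weaker inhibition. Compound 3 is therefore estimated to give about 75000 nM, within 25000 nM to 200000 nM.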

Compound 3, half-maximal inhibitory concentration: > 100000 nM
Compound 3: a limit, no number (the forecaster's own chance of this, stated with the estimate: 35%); middle value at least 1.3-fold (0.12 log units) from the limit.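

In this assay, going by these compounds alone, putting hydrogen in place of the chloro para to the allyloxy group gives an at least 1.8-fold higher number from compound 2 to compound 3 (0.26 log units; that floor lies within the scatter), and the one compound with a number loses it. That step is only a floor, so the true size of the change stays hidden and the data do not yet separate the two compounds beyond the scatter: the limit of > 100000 nM in this assay, at which 2 of the 3 values shown sit. The step from compound 1 to compound 3 cannot be read, as both values are limits.

From the compounds shown here alone, how far compound 3 lies past its limit remains open, as does whether the chloro itself matters at this place. A bromine atom, a methoxy group or an amine in the same spot could show whether the number of compound 2 moves with the group there.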